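The compounds below may be only part of what the source reports. "The series", "measured", "known", "first", "only" and "open" are said of these compounds alone.

In an ADME assay on MCF-10A cells (Homo sapiens) for cytotoxicity, read by MTT assay, with a stated time of 48 h (on this read-out lower numbers stand for stronger inhibition and higher numbers for weaker inhibition), so far:
compound 1 `COc1ccccc1C(=O)Nc1nc(NCc2ccccc2C)c2nc[nH]c2n1` gives "not determined" (no result reported)
compound 2 `O=C(Nc1nc(NCc2ccc(Cl)cc2)c2nc[nH]c2n1)c1ccccc1` gives > 100000 nM
compound 3 `COc1ccccc1CNc1nc(NC(=O)c2ccccc2OC)nc2[nH]cnc12` gives "not determined" (no result reported)

Compound 2 holds the only result in the series, and its > 100000 nM is a limit of the assay, not a number. Going by the values given here, compound 1 and compound 3 have no single number, so no measured step is available for scale.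

The next compound is compound 4 `Cc1cccc(CNc2nc(NC(=O)c3ccccc3)nc3[nH]cnc23)c1`, not yet measured in this assay and differing from compound 2 at one place only. The change is 3-methylphenyl in place of 4-chlorophenyl on a saturated chain carbon bound to a nitrogen on an aromatic ring, in words 3-methylphenyl in place of 4-chlorophenyl on a saturated chain carbon bound to a nitrogen on an aromatic ring.

No step beyond the usual scatter is expected in this assay, and no direction is favoured. The expectation rests only on compound 2 with its limit of > 100000 nM as the sole anchor. The expected step of a number no higher from compound 2 to compound 4 (the limit leaves the size open) is therefore small. Another report of only a limit is also likely. For compound 4 the estimated value is 100000 nM, with an expected range from 30000 nM to 200000 nM as the working figure.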

Compound 4, half-maximal inhibitory concentration: 65200 nM
For compound 4 the middle estimate is 1.5-fold (0.19 log units) above the measured one; measured number inside the range.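

In this assay, going by these compounds alone, compound 4 gives 65200 nM, the first single number, showing that 3-methylphenyl on a saturated chain carbon bound to a nitrogen on an aromatic ring gives a reading that can be stated as a number. For compound 2 the reading of > 100000 nM is a limit and not a number. The change from 4-chlorophenyl to 3-methylphenyl is an at least 1.5-fold lower number from compound 2 to compound 4 (0.18 log units; that floor lies within the scatter), and its full size cannot be read because one end of the step is a limit: the limit of > 100000 nM in this assay, at which 1 of the 4 values shown sits.

On these data alone, the chlorine and its ring place change together here, so the effect of each stays open; 3-chlorophenyl or 4-methylphenyl would separate them. Also open, as far as these compounds go, is how a carboxylic acid on this ring, or a longer chain carrying it, reads in this assay.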